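This account rests on a few compounds, and the source may have more. Where it says the series, first, only, none or still open, it means among the compounds named here.

Working notes on the series. Compound 1, `CCC/C=C/C(=O)N(Cc1ccc(OC)c(O)c1)c1cc(OC)c(OC)c(OC)c1`, is the reference point: in a functional assay on HCT-116 cells (Homo sapiens) for inhibition, read by MTT assay, with a stated time of 48 h (a higher number here means a weaker inhibitor, a lower number a stronger inhibitor), compound 1 gives 95 nM. Two further measured compounds share the core but carry no acyl group on the nitrogen. Compound 2, `COc1ccc(CNc2cc(OC)c(OC)c(OC)c2)cc1`, gives 18400 nM in this assay, and compound 3, `COc1cc(NCc2cccc(O)c2)cc(OC)c1OC`, gives 67700 nM. Compound 1 therefore holds the lowest of the three numbers, and both gaps to the others are well beyond the usual scatter, so compound 1 is the strongest inhibitor of the three measured. Among the measured compounds shown here, no single-point step between the measured compounds is available, so no measured step can be used directly for the next compound.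

Compound 4, `COc1ccc(CN(C(=O)CCCCCl)c2cc(OC)c(OC)c(OC)c2)cc1O`, is the next compound to be measured. It keeps the core and the acyl-bearing nitrogen of compound 1; the change is 4-chlorobutyl in place of pent-1-en-1-yl on a carbonyl carbon. The amide and its chain length are retained, only the chain itself is exchanged. With nothing measured across this kind of exchange, the expectation rests on compound 1 alone: a modest weakening is expected, close to the scatter, as the step of a 3.2-fold higher number from compound 1 to compound 4 (0.50 log units; beyond the scatter). For compound 4 the estimate in this assay is 300 nM, within a range from 100 nM to 1000 nM.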

Compound 4, half-maximal inhibitory concentration: 220 nM
For compound 4 the middle estimate is 1.4-fold (0.13 log units) above the measured one; low and high end bracket the measured number.
By their numbers in this assay, from the lowest: compound 1; then compound 4; then compound 2; then compound 3.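

In this assay, 4-chlorobutyl in place of pent-1-en-1-yl on a carbonyl carbon whose other neighbours are amide-type nitrogen gives a 2.3-fold higher number from compound 1 to compound 4 (0.36 log units; beyond the scatter) and counts as a modest step. Among the compounds shown here, the earlier compounds carried no acyl group other than that of compound 1, so this is the first reading of how much this position responds to a change of the chain itself: with the same count of heavy atoms, the double bond outside aromatic rings leaves, chlorine enters, and the number shifts only modestly. No measurement of any property of the two chains is at hand to account for the size of this step.

This single exchange changes two things at once, so the shares of the lost double bond and of the chlorine stay unresolved, and a plain pentyl chain would be the comparison that separates them. How far the position stretches also remains open: a longer chain, or an amine or a carboxylic acid at the end of the chain, lies outside the compounds shown.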